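Thiophene attachment point on the bicyclic ester series

This account rests on a few compounds, and the source may have more. Where it says the series, first, only, none or still open, it means among the compounds named here.

Three compounds of this series have numbers in an assay on HEK293 cells for displacement of a labelled ligand from adenosine receptor A2b (Homo sapiens), with a stated time of 30 min; on this read-out higher numbers stand for weaker inhibition and lower numbers for stronger inhibition. Compound 1 `CCOC(=O)C1=C(C)Nc2nccn2C1c1ccco1` gives 108 nM. Compound 2 `CC1=C(C(=O)OC(C)C)C(c2ccco2)n2ccnc2N1` gives 85.6 nM, and the change a 1.3-fold lower number from compound 1 to compound 2 (0.10 log units; within the scatter) alters nothing of note. Compound 3 `CC1=C(C(=O)OC(C)C)C(c2cccs2)n2ccnc2N1` gives 728 nM, which is the highest of the three numbers, beyond the scatter from both others; the step of an 8.5-fold higher number from compound 2 to compound 3 (0.93 log units; beyond the scatter) is the only one in the set that touches the aromatic group on the saturated ring carbon.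

Compound 4 `CC1=C(C(=O)OC(C)C)C(c2ccsc2)n2ccnc2N1` differs from compound 3 only in thiophen-3-yl in place of thiophen-2-yl on a saturated ring carbon. For the measured compounds named here, no measured step in this assay bears directly on moving the attachment point of the thiophene; the step from compound 2 to compound 3 concerns a change of ring heteroatom, not of attachment, and gives no direction for this case. The expectation is therefore a number near that of compound 3, with the step of a 1.2-fold lower number from compound 3 to compound 4 (0.08 log units; within the scatter) expected to stay within or close to the scatter. Compound 4 is estimated at 600 nM in this assay, with a range of 200 nM to 2000 nM.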

Compound 4, inhibition constant: 847 nM
Beside the measured number, compound 4's estimate is 1.4-fold (0.15 log units) below it, and the stated range covers the measured number.
By their numbers in this assay, from the lowest: compounds 2 and 1 (each within the scatter of the next); then compounds 3 and 4 (each within the scatter of the next).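

In this assay, moving the attachment point of the thiophene gives a 1.2-fold higher number from compound 3 to compound 4 (0.07 log units; within the scatter) and so does not separate thiophen-2-yl from thiophen-3-yl on this saturated ring carbon. The change away from furan-2-yl gives an 8.5-fold higher number from compound 2 to compound 3 (0.93 log units; beyond the scatter) and also a 9.9-fold higher number from compound 2 to compound 4 (1.00 log units; beyond the scatter) as steps beyond the scatter, so the higher number is not confined to one thiophene attachment point in this pair of compounds. Nothing available explains why both thiophene compounds part from the furan compound.

The compounds shown leave open whether furan-3-yl would match furan-2-yl or the two thiophene compounds. They also leave open whether phenyl at this carbon, or a thiophene carrying an aminomethyl group, would follow the same trend, and whether the thiophene results hold with the ethyl ester of compound 1.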